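Swapping the benzimidazole for isoquinoline: plasma binding expected

A few compounds are considered here, and "the series" means these few. Any claim that something is new, unique, unknown or untested is made for them only; others in the source may bear on it.

Measured compounds:
- compound 1, `Cn1cnc2ccc(-c3cc(F)c(Cn4cnc5cnccc5c4=O)c(F)c3)cc21`: 0.04
- compound 2, `Cn1cc2c(-c3cc(F)c(CN4CCc5ncccc5C4=O)c(F)c3)cccc2n1`: 0.01
- compound 3, `Cn1cc2cc(-c3cc(F)c(Cn4c(=O)cnc5ncccc54)c(F)c3)ccc2n1`: 0.04

Of the compounds shown here, three sharing a central difluorophenyl core have been measured in an ADME assay on a cell-free system (plasma, Rattus norvegicus) for protein binding; a higher number here means a larger unbound share of the compound, a lower number a smaller unbound share. Compound 1 gives 0.04 in this assay, and compound 3 gives 0.04, a reading level with compound 1 at the digits shown, so the two cannot be told apart. Compound 2 gives 0.01, a clearly lower unbound fraction than compound 1, and that gap lies beyond the usual scatter. Compound 1 therefore stands together with compound 3 at the upper end of these three values, with compound 2 below them.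

Compound 4, `O=c1c2ccncc2ncn1Cc1c(F)cc(-c2ccc3cnccc3c2)cc1F`, has not yet been measured in this assay. It differs from compound 1 in one place: isoquinolin-6-yl in place of 1-methyl-1H-benzimidazol-6-yl on an aromatic carbon. The remainder of the molecule, including the two fluoro groups and the large group para to the point of change, is kept.

Among the compounds with values here, no measured pair in this set isolates this particular swap, so there is no directly comparable step to lean on. The expectation is a small change, if any, from compound 1 to compound 4, with the new value most likely staying close to compound 1 and not moving beyond the scatter. The estimated step is a 1.3-fold lower number from compound 1 to compound 4 (0.12 log units; within the scatter). Compound 4 is expected to give about 0.03 in this assay, with a plausible range from 0.01 to 0.08.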

Compound 4, unbound fraction: 0.03
Beside the measured number, compound 4's estimate shows no gap at the digits printed; low and high end bracket the measured number.
By their numbers in this assay, from the lowest: compound 2; then compounds 4, 1 and 3 (each within the scatter of the next).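

On the aromatic carbon meta to two fluoro groups and para to a large group, isoquinolin-6-yl takes the place of 1-methyl-1H-benzimidazol-6-yl with no readable effect in this assay: the step is a 1.3-fold lower number from compound 1 to compound 4 (0.12 log units; within the scatter). Within the data shown here, this is the first pair here that differs in one place, so it is the first reading of this position alone, and it shows that a six-membered aromatic ring with 1 hetero atom can replace a five-membered aromatic ring with 2 hetero atoms, and 1 hydrogen-bond acceptor can stand where the leaving group has 2, without the result moving outside the usual variation between repeat measurements. Nothing at hand explains why the reading holds steady across this swap.

As far as these compounds go, both groups compared here are two-ring aromatic groups with no net charge, so it remains open whether a different kind of group at this place, such as an amine or a carboxylic acid, would leave this assay just as steady. From the compounds shown here alone, it is also open whether the same swap would give a similar step if the large group para to the point of change were replaced.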